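A few compounds are considered here, and "the series" means these few. Any claim that something is new, unique, unknown or untested is made for them only; others in the source may bear on it.

Measured in a functional assay on Raji cells (Homo sapiens) for antiproliferative activity, read by MTT assay, with a stated time of 6 days; a higher number here means a weaker inhibitor, a lower number a stronger inhibitor:
- compound 1 `CC(=O)O[C@@H]1C=CC(=O)O[C@@H]1[C@@H](COC(=O)c1ccc([N+](=O)[O-])cc1)OC(C)=O`: 18500 nM
- compound 2 `O=C1C=C[C@@H](OCc2ccccc2)[C@@H]([C@@H](COC(=O)/C=C/c2ccccc2)OCc2ccccc2)O1`: 1330 nM
- compound 3 `CC(=O)O[C@@H]1C=CC(=O)O[C@@H]1[C@@H](COC(=O)/C=C/c1ccc(F)cc1)OC(C)=O`: 2310 nM

Compound 2 sits at the low end of these numbers together with compound 3, the two lying within the scatter of each other. Compound 1 stands apart from compound 2 by a gap beyond the scatter, on the higher side.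

The next compound is compound 4 `O=C1C=C[C@@H](OCc2ccccc2)[C@@H]([C@@H](CO)OCc2ccccc2)O1`. The change is hydrogen in place of (2-phenylethenyl)carbonyl on an oxygen on a saturated carbon, which leaves hydroxymethyl where (((2-phenylethenyl)carbonyl)oxy)methyl stood.

Within the data shown here, only one measured step bears on this, and only indirectly: an 8.0-fold lower number from compound 1 to compound 3 (0.90 log units; beyond the scatter). That step exchanges one group on a carbonyl carbon for another, whereas here the whole (2-phenylethenyl)carbonyl leaves. Among the measured compounds shown here, no measured pair shows such a loss. Still, that step shows that the number in this assay can move beyond the scatter with the group on the carbonyl carbon, so a move to a higher number is expected here, with wide uncertainty.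

The expected change is a 3.4-fold higher number from compound 2 to compound 4 (0.53 log units; beyond the scatter). For compound 4 the estimate is 4500 nM, with an expected range of 1300 nM to 16000 nM.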

Compound 4, half-maximal inhibitory concentration: 10 nM
Compound 4: the middle estimate sits 450-fold (2.65 log units) above what was measured; measured number below the stated range.
By their numbers in this assay, from the lowest: compound 4; then compounds 2 and 3 (each within the scatter of the next); then compound 1.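

In this assay, loss of the (2-phenylethenyl)carbonyl from this oxygen gives a 130-fold lower number from compound 2 to compound 4 (2.12 log units; beyond the scatter), leaving hydroxymethyl in place of (((2-phenylethenyl)carbonyl)oxy)methyl. The earlier step, an 8.0-fold lower number from compound 1 to compound 3 (0.90 log units; beyond the scatter), only exchanged one group on a carbonyl carbon for another, whereas this step shows the oxygen with no such group at all, and on the core of compound 2 a low number does not require the (2-phenylethenyl)carbonyl; its presence goes with a far higher number. Nothing at hand accounts for the size of this step.

Open, on these data alone, is whether the free hydroxy matters in itself or whether removing the (2-phenylethenyl)carbonyl is enough: a methoxy, an acetyl ester or an amine in place of the hydroxy would separate these two readings. Also open, as far as these compounds go, is whether the same change carries over to the compounds bearing acetate groups, such as compound 3, as this step is read only on the core of compound 2.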